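This account rests on a few compounds, and the source may have more. Where it says the series, first, only, none or still open, it means among the compounds named here.

Compound 1 `COc1ccc(-c2cnc(NC(=O)c3ccccc3F)n2C)cc1`: > 100000 nM
Compound 2 `Cn1c(-c2ccccc2)cnc1NC(=O)c1cc(-c2ccccn2)[nH]n1`: > 50000 nM

In a toxicity assay on THP-1 cells (Homo sapiens) for inhibition (on this read-out lower numbers stand for higher toxicity in this test and higher numbers for lower toxicity in this test), compound 1 gives > 100000 nM, a limit of the assay and not a number, sitting at the limit of > 100000 nM in this assay, at which 1 of the 2 values shown sits. Compound 2 gives > 50000 nM, likewise a limit, at the limit of > 50000 nM in this assay, at which 1 of the 2 values shown sits. Compound 3 `COc1ccc(-c2cnc(NC(=O)c3ccc(F)cc3)n2C)cc1` is not yet measured in this assay. It differs from compound 1 in one place: 4-fluorophenyl in place of 2-fluorophenyl on a carbonyl carbon. Going by the values given here, no step between the two measured compounds is available, so the step from compound 1 to compound 3 is expected to stay within the scatter in this assay, estimated as a number no higher from compound 1 to compound 3 (the limit leaves the size open). Compound 3 is therefore expected near the limit, at 100000 nM (range 30000 nM to 300000 nM).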

Compound 3, half-maximal cytotoxic concentration: >= 50000 nM
Compound 3: only a limit was reported; the forecaster's own chance of this, stated with the estimate: 85%; the middle value is on the limit's open side.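

No step can be read from compound 1 to compound 3: both values are limits of the assay. The compounds shown leave open whether 4-fluorophenyl in place of 2-fluorophenyl on a carbonyl carbon shifts the half-maximal cytotoxic concentration at all.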